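Removing the bromo group from compound 2

A few compounds are considered here, and "the series" means these few. Any claim that something is new, unique, unknown or untested is made for them only; others in the source may bear on it.

Notes on a short series that shares one core and varies the chain on oxygen. In a functional assay, with a stated time of 30 min (a lower number here means a stronger inhibitor, a higher number a weaker inhibitor), compound 1 `CCOc1cc(OC)c(Br)cc1C(C)=O` gives 46800000 nM, compound 2 `CCCCOc1cc(OC)c(Br)cc1C(C)=O` gives 42300000 nM and compound 3 `CCCCCCCCCCOc1cc(OC)c(Br)cc1C(C)=O` gives 35100000 nM. Compound 2 cannot be separated from either of the other two on these numbers. The measured steps are a 1.1-fold lower number from compound 1 to compound 2 (0.04 log units; within the scatter) and a 1.2-fold lower number from compound 2 to compound 3 (0.08 log units; within the scatter), so the chain changes tested so far leave the read-out flat.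

The next compound is compound 4 `CCCCOc1cc(OC)ccc1C(C)=O`, not yet measured. The change is hydrogen in place of bromo on an aromatic carbon, para to a butoxy group: hydrogen in place of bromo on an aromatic carbon.

All three measured compounds carry the bromo group, so neither measured step changes this position. Those steps bear on the question only indirectly, and the data give no size or direction for removing the group. Going by the values given here, with no measured precedent, no step beyond the scatter is assumed in this assay, and the range is kept wide to allow for a real change in either direction.

The expected result is a 1.1-fold higher number from compound 2 to compound 4 (0.03 log units; within the scatter). For compound 4 the estimated value is 45000000 nM, with an expected range of 18000000 nM to 110000000 nM.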

Compound 4, half-maximal inhibitory concentration: 43300000 nM
For compound 4 the middle estimate is 1.0-fold (0.02 log units) above the measured one; the range from low to high includes it.
By their numbers in this assay, from the lowest: compounds 3, 2, 4 and 1 (each within the scatter of the next).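

The series now has a step at the aromatic carbon para to a butoxy group, and in this assay hydrogen in place of bromo gives a 1.0-fold higher number from compound 2 to compound 4 (0.01 log units; within the scatter), so the bromo group can be lost from this carbon with no step beyond the scatter. Compound 4 and compound 2 cannot be separated on these numbers, which extends the flat picture from the chain on oxygen to this position on the ring, at least with the butoxy group in place. No measurement at hand offers an explanation for this result.

Still open, going by these compounds, is whether a group of another kind on this aromatic carbon, such as an amine or a carboxylic acid, would give a step beyond the scatter, as a single replacement of bromo by hydrogen says nothing about other groups there. The acetyl group and the methoxy group also remain untested, as every compound shown carries both, so no step here bears on either of them.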